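From a Hydroxamate to a Carboxy-Bearing Benzamide

The compounds below may be only part of what the source reports. "The series", "measured", "known", "first", "only" and "open" are said of these compounds alone.

Compound 1 `O=C(NO)c1ccc(CNc2nccc(-c3cccnc3)n2)cc1` is the reference point of this series. In an assay for inhibition of histone deacetylase 8 (Homo sapiens), read by fluorescence, with stated times of 15 min and 60 min (on this read-out higher numbers stand for weaker inhibition and lower numbers for stronger inhibition), compound 1 gives 410 nM. Compound 2 `Nc1cc(Br)ccc1NC(=O)c1ccc(CNc2nccc(-c3cccnc3)n2)cc1` carries a 2-amino-4-bromophenyl group in place of the hydroxy on the amide-type nitrogen. In this assay compound 2 reaches only a limit of the assay, > 20000 nM. Among the compounds with values here, the one measured step, an at least 48-fold higher number from compound 1 to compound 2 (1.68 log units; beyond the scatter), rests on (the limit of > 20000 nM in this assay, at which 1 of the 2 values shown sits), so the true size of that loss is open, and compound 2 stands at the weak edge of what has been recorded.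

Compound 3 `Nc1cc(C(=O)O)ccc1NC(=O)c1ccc(CNc2nccc(-c3cccnc3)n2)cc1` differs from compound 2 by carboxy in place of bromo on an aromatic carbon. Within the data shown here, no measured step touches this exchange: the only step recorded concerns the hydroxy-to-aminophenyl switch, not the bromo-to-carboxy change. From compound 2, which sits at a limit, no direction for this step can be read, and the expectation is that compound 3 stays near the weak end. Compound 3 is therefore estimated at 30000 nM, with a range from 8000 nM to 120000 nM. For compound 3 this estimate corresponds to an expected step that the limit leaves unreadable from compound 2 to compound 3.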

Compound 3, half-maximal inhibitory concentration: > 20000 nM
Compound 3 ended at the assay's limit (the forecaster's own chance of this, stated with the estimate: 65%); the middle value does not contradict the limit.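

In this assay compound 3 also stops at a limit of the assay, > 20000 nM, so carboxy in this place, meta to an amino group and para to a large group, gives no readable value, just as bromo gave none. The loss against the hydroxy of the reference compound therefore now holds for a second substituted aminophenyl group, with an at least 48-fold higher number from compound 1 to compound 3 (1.68 log units; beyond the scatter), and this figure marks only the least the loss can be, not its true size. The step that exchanges bromo for carboxy cannot be read, so neither a gain nor a loss can be assigned to it, because both values are limits: the limit of > 20000 nM in this assay, at which 2 of the 3 values shown sit.

The compounds shown leave open how weak compound 2 and compound 3 really are, and whether they differ from each other at all. They also leave open whether a plain 2-aminophenyl group, or a fluoro or a methoxy in this place, would bring the number back inside the range of this assay.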